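This account rests on a few compounds, and the source may have more. Where it says the series, first, only, none or still open, it means among the compounds named here.

In a functional assay on A20 cells (Mus musculus) for inhibition, with stated times of 1 h, 16 h and 24 h (a lower number here means a stronger inhibitor, a higher number a weaker inhibitor), compound 1 (`CC(C)(C#N)NC(=O)[C@@H]1C[C@@H](S(=O)(=O)c2ccccc2)C[C@H]1C(=O)N1CCOCC1`) gives 43 nM and compound 2 (`N#CC1(NC(=O)[C@@H]2C[C@@H](S(=O)(=O)c3ccccc3)C[C@H]2C(=O)N2CC3(COC3)C2)CC1`) gives 248 nM as the higher of the two numbers. That makes compound 2 the weaker inhibitor of the pair, by a gap beyond the usual scatter. These two compounds differ in more than one place, so their gap cannot be pinned on any single group.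

Compound 3 (`N#CC1(NC(=O)[C@@H]2C[C@@H](S(=O)(=O)c3ccccc3)C[C@H]2C(=O)N2CCC(O)CC2)CC1`) keeps the core of compound 2 and changes only the group on a carbonyl carbon (a group of 7 heavy atoms (5 carbon, 1 nitrogen, 1 oxygen; one six-membered non-aromatic ring with 1 hetero atom) in place of a group of 7 heavy atoms (5 carbon, 1 nitrogen, 1 oxygen; 2 four-membered non-aromatic rings with 1 hetero atom each), on a carbonyl carbon). A 4-hydroxypiperidin-1-yl group, with one six-membered non-aromatic ring, replaces the group with 2 four-membered non-aromatic rings. Among the compounds with values here, no measured pair shows this exchange, so any forecast is loose. Within the data shown here, the only guide is compound 1, which at 43 nM also carries a six-membered non-aromatic ring on that carbonyl carbon, although it differs from compound 3 elsewhere too. The expected result in this assay is a 2.3-fold lower number from compound 2 to compound 3 (0.35 log units; beyond the scatter) as a modest move toward a lower number. Compound 3 is estimated at 110 nM (expected range 35 nM to 350 nM) once it is measured.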

Compound 3, half-maximal inhibitory concentration: 371 nM
Estimate against measurement, compound 3: 3.4-fold (0.53 log units) below, outside the stated range (above it).
By their numbers in this assay, from the lowest: compound 1; then compounds 2 and 3 (each within the scatter of the next).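

In this assay, putting 4-hydroxypiperidin-1-yl on this carbonyl carbon in place of the group with 2 four-membered non-aromatic rings gives a 1.5-fold higher number from compound 2 to compound 3 (0.17 log units; within the scatter). Within the data shown here, this is the first exchange at this position that can be read on its own, and the two groups cannot be told apart here, even though one has a single six-membered ring and a hydrogen-bond donor, and the other has neither. No measurement shown explains why two such different groups give numbers this close.

As far as these compounds go, compound 1 differs from both compound 2 and compound 3 in more than one place, so how its value divides between its group on the carbonyl carbon and the other part that differs stays open. From the compounds shown here alone, it is also open whether this position stays as indifferent with a charged or more strongly hydrogen-bonding group, such as 4-aminopiperidin-1-yl or 4-carboxypiperidin-1-yl, on the same carbonyl carbon.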